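This account rests on a few compounds, and the source may have more. Where it says the series, first, only, none or still open, it means among the compounds named here.

Working notes. Three analogues on the shared core carry a measured permeability. In an ADME assay for permeability, using PAMPA, with a stated time of 4 h (a higher number here means that the compound crosses the layer faster, a lower number that the compound crosses the layer more slowly), compound 1 `Cn1c(COc2cccc(C(=O)O)c2)nc2ccc(Oc3ccc(F)cc3)nc21` gives 8.6 10^-6 cm/s, compound 2 `Cn1c(COc2cccc(C(=O)O)c2)nc2cnc(Oc3ccc(Cl)c(F)c3)cc21` gives 11.2 10^-6 cm/s, and compound 3 `Cn1c(COc2cccc(C(=O)O)c2)nc2ccc(Oc3cccc(Cl)n3)cc21` gives 7.6 10^-6 cm/s. Compound 3 holds the lowest of the three numbers, yet its gaps to compound 1 and to compound 2 both lie within the scatter, so no order among them is claimed. Compound 4 `Cn1c(COc2cccc(C(=O)O)c2)nc2ccc(Oc3ncccc3Cl)cc21` differs from compound 3 in one place: 3-chloropyridin-2-yl in place of 6-chloropyridin-2-yl on an oxygen on an aromatic ring. Within the data shown here, no step between measured compounds covers this kind of change, so in this assay a step of no size beyond the scatter is expected, in either direction. For compound 4 the estimated value in this assay is 8 10^-6 cm/s, with a range of 5 10^-6 cm/s to 13 10^-6 cm/s, the expected step being a 1.1-fold higher number from compound 3 to compound 4 (0.02 log units; within the scatter).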

Compound 4, apparent permeability: 8.1 10^-6 cm/s
For compound 4 the middle estimate is 1.0-fold (0.01 log units) below the measured one; low and high end bracket the measured number.
By their numbers in this assay, from the lowest: compounds 3, 4, 1 and 2 (each within the scatter of the next).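

Among these compounds, with 3-chloropyridin-2-yl in place of 6-chloropyridin-2-yl on an oxygen on an aromatic ring, this assay shows a 1.1-fold higher number from compound 3 to compound 4 (0.03 log units; within the scatter), the only one-place step read so far. Among the compounds shown here, at this position, the same atoms joined differently leave the read-out within the scatter, which the earlier compounds, with no one-place pair among them, could not show. No measurement offers an explanation for this result.

From the compounds shown here alone, whether an amine or a methoxy group in place of the chlorine would also stay within the scatter remains open. Also open, going by these compounds, is whether this exchange would give a similar step on the core of compound 1 or compound 2.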